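A few compounds are considered here, and "the series" means these few. Any claim that something is new, unique, unknown or untested is made for them only; others in the source may bear on it.

Measured compounds:
compound 1 `Clc1cccc(Nc2ccc(N3CC4CC(C3)N4)cn2)c1` gives 2.2 nM in an assay on cell membranes for displacement of a labelled ligand from Neuronal acetylcholine receptor; alpha4/beta2 (Rattus norvegicus); on this read-out higher numbers stand for weaker inhibition and lower numbers for stronger inhibition
compound 2 `Oc1ccc(Nc2ccc(N3CC4CC(C3)N4)cn2)cc1` gives 7.1 nM in this assay
compound 3 `COc1ccc(Nc2ccc(N3CC4CC(C3)N4)cn2)cc1` gives 7.3 nM in this assay

Compound 3 has the highest number of the three, but its nearest neighbour, compound 2, sits within the scatter, so the two cannot be ordered; only compound 1 is set apart, with a 3.2-fold higher number from compound 1 to compound 2 (0.51 log units; beyond the scatter) opening the gap. Compound 4 `Fc1ccc(Nc2ccc(N3CC4CC(C3)N4)cn2)cc1` is not yet measured. It differs from compound 3 as follows: fluoro in place of methoxy on an aromatic carbon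

Two measured steps offer some guidance. The step of a 1.0-fold higher number from compound 2 to compound 3 (0.01 log units; within the scatter) shows that methyl in place of hydrogen on the oxygen changed little. The step of a 3.2-fold higher number from compound 1 to compound 2 (0.51 log units; beyond the scatter) shows that a ring carrying a halogen gave a lower number than one carrying a hydroxyl, though the halogen there sat at a different place on the ring, so it is only a loose pointer. A fluoro in place of methoxy is therefore expected to give compound 4 a somewhat lower number, a 1.8-fold lower number from compound 3 to compound 4 (0.26 log units; within the scatter), though a step staying within the scatter would not surprise. Compound 4 is thus estimated at 4 nM, with a range from 1.5 nM to 11 nM.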

Compound 4, inhibition constant: 2.38 nM
The estimate for compound 4 lay 1.7-fold (0.23 log units) above the measured number; measured number inside the range.
By their numbers in this assay, from the lowest: compounds 1 and 4 (each within the scatter of the next); then compounds 2 and 3 (each within the scatter of the next).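

In this assay, the ring carbon para to a large group proves sensitive to what it carries, with fluoro set apart from both oxygen groups: a 3.1-fold lower number from compound 3 to compound 4 (0.49 log units; beyond the scatter) and a 3.0-fold lower number from compound 2 to compound 4 (0.47 log units; beyond the scatter) whereas the earlier swap of hydrogen for methyl on the oxygen showed no such separation. The halogen link that the earlier compounds only hinted at also gains support, since a 1.1-fold higher number from compound 1 to compound 4 (0.03 log units; within the scatter) leaves the 4-fluorophenyl and 3-chlorophenyl compounds indistinguishable, and among these four compounds both halogen-bearing rings give lower numbers than both oxygen-bearing rings, with no compound going against this. Nothing shown here explains why fluoro behaves differently from hydroxy and methoxy.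

Compound 1 and compound 4 differ in both the halogen and its place on the ring, so a chloro at the carbon that carries fluoro in compound 4 would be needed to separate those two changes. As far as these compounds go, how this carbon responds to an amine, a carboxylic acid or a chain longer than methoxy also remains open.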